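Methyl to hydroxy: what to expect for compound 4

A few compounds are considered here, and "the series" means these few. Any claim that something is new, unique, unknown or untested is made for them only; others in the source may bear on it.

Compound 1 `CN(C)Cc1cc(C(=O)/C=C/c2ccccc2Cl)cc(CN(C)C)c1O`: 9550 nM
Compound 2 `CN(C)Cc1cc(C(=O)/C=C/c2ccc(Cl)c(Cl)c2)cc(CN(C)C)c1O`: 2350 nM
Compound 3 `Cc1ccc(/C=C/C(=O)c2cc(CN(C)C)c(O)c(CN(C)C)c2)cc1`: 17800 nM

In a functional assay on cells (Tumor Cell line, Homo sapiens) for cytotoxicity (a lower number here means a stronger inhibitor, a higher number a weaker inhibitor), compound 3 gives 17800 nM, which matches compound 1 within the scatter, a 1.9-fold higher number from compound 1 to compound 3 (0.27 log units; within the scatter). Compound 2 stands clearly apart, a 7.6-fold higher number from compound 2 to compound 3 (0.88 log units; beyond the scatter).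

Compound 4 `CN(C)Cc1cc(C(=O)/C=C/c2ccc(O)cc2)cc(CN(C)C)c1O` changes one group of compound 3: hydroxy in place of methyl on an aromatic carbon. Among the compounds with values here, no measured compound carries a hydroxy in this place, so the evidence is indirect. Swaps of the substituted phenyl group give steps of modest size at most, such as a 4.1-fold lower number from compound 1 to compound 2 (0.61 log units; beyond the scatter), and only those involving compound 2 exceed the scatter. A small step towards a lower number is therefore expected in this assay, though its direction is uncertain. The estimated step is a 1.6-fold lower number from compound 3 to compound 4 (0.21 log units; within the scatter). For compound 4, the expected value is 11000 nM, with an estimated range of 3500 nM to 30000 nM.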

Compound 4, half-maximal inhibitory concentration: 39800 nM
Compound 4: the middle estimate sits 3.6-fold (0.56 log units) below what was measured; the measured number lies above the stated range.
By their numbers in this assay, from the lowest: compound 2; then compounds 1 and 3 (each within the scatter of the next); then compound 4.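

Hydroxy in place of methyl on this aromatic carbon brings a 2.2-fold higher number from compound 3 to compound 4 (0.35 log units; beyond the scatter) in this assay, so this position responds to a change that the earlier compounds did not test. The 4-hydroxyphenyl compound is the weakest of the four, with a 4.2-fold higher number from compound 1 to compound 4 (0.62 log units; beyond the scatter) and a 17-fold higher number from compound 2 to compound 4 (1.23 log units; beyond the scatter) as its steps from the chlorinated compounds. Nothing available explains why the hydroxy weakens the compound. From the compounds shown here alone, whether a methoxy or an amine at this position would track the hydroxy or the methyl remains open.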